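Sulfonyl Aryl Variation Against a Flat Assay Limit

A few compounds are considered here, and "the series" means these few. Any claim that something is new, unique, unknown or untested is made for them only; others in the source may bear on it.

Compound 1 `O=S(=O)(Nc1ccc(-c2nc3ccccc3o2)cc1)c1ccccc1O` — in an assay on isolated protein for inhibition of malate dehydrogenase, mitochondrial (Sus scrofa), with stated times of 45 min and 30 min (on this read-out lower numbers stand for stronger inhibition and higher numbers for weaker inhibition), compound 1 reaches only a limit, > 63000 nM.
Compound 2 `C=Cc1ccc(S(=O)(=O)Nc2ccc(-c3nc4ccccc4o3)cc2)cc1` — in this assay compound 2 likewise returns a limit, > 63000 nM.
Compound 3 `O=S(=O)(Nc1ccc(-c2nc3ccccc3o2)cc1)c1ccccc1F` — in this assay compound 3 also stops at a limit, > 63000 nM.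

Compound 3 thus stands at the edge of this assay, where every measured value sits (the limit of > 63000 nM in this assay, at which 3 of the 3 values shown sit). Compound 4 `COc1cccc(S(=O)(=O)Nc2ccc(-c3nc4ccccc4o3)cc2)c1` differs from it in one place: 3-methoxyphenyl in place of 2-fluorophenyl on a sulfonyl sulfur. The steps that touch compound 3 are a step that the two limits leave unreadable from compound 2 to compound 3 and a step that the two limits leave unreadable from compound 1 to compound 3, while a step that the two limits leave unreadable from compound 1 to compound 2 joins the other two; none of them can be read, since both ends of each rest on (the limit of > 63000 nM in this assay, at which 3 of the 3 values shown sit). No readable step in either direction is therefore expected. Compound 4 is estimated at 80000 nM (20000 nM to 300000 nM), most probably reported again as a limit. The expected step is a step that the limit leaves unreadable from compound 3 to compound 4.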

Compound 4, half-maximal inhibitory concentration: > 63000 nM
Compound 4: a limit, no number; the forecaster's own chance of this, stated with the estimate: 85%; the middle value does not contradict the limit.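

Compound 4 also returns only a limit, so none of its steps from compound 1, compound 2 or compound 3 can be read in this assay: the limit of > 63000 nM in this assay, at which 4 of the 4 values shown sit.

The compounds shown leave open whether any aryl group on the sulfonyl sulfur gives a readable inhibition in this assay.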